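A few compounds are considered here, and "the series" means these few. Any claim that something is new, unique, unknown or untested is made for them only; others in the source may bear on it.

Measured so far in a functional assay on BJAB cells (Homo sapiens) for antiproliferative activity, with a stated time of 4 days; on this read-out lower numbers stand for an effect already at smaller amounts and higher numbers for an effect only at larger amounts of compound:
- compound 1, `Cc1nn(-c2nc(-c3ccc(Cl)c(Cl)c3)c(SC(C)C)s2)c(C(=O)O)c1Cc1ccccc1[N+](=O)[O-]`: 20000 nM
- compound 2, `CCOc1ncccc1-c1c(C)nn(-c2nc(-c3ccc(Cl)c(Cl)c3)c(SC(C)C)s2)c1C(=O)O`: 11000 nM
- compound 3, `COc1cc(-c2c(C)nn(-c3nc(-c4ccc(Cl)c(Cl)c4)c(SC(C)C)s3)c2C(=O)O)cc(C(F)(F)F)c1`: 1380 nM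

Compound 3 stands at the lowest number of the three, and both of its steps from the other compounds lie beyond the scatter: a 14-fold lower number from compound 1 to compound 3 (1.16 log units; beyond the scatter) and an 8.0-fold lower number from compound 2 to compound 3 (0.90 log units; beyond the scatter). The remaining pair, a 1.8-fold lower number from compound 1 to compound 2 (0.26 log units; within the scatter), stays within the scatter, so compounds 1 and 2 are not separated on this read-out.

The next compound is compound 4, `Cc1nn(-c2nc(-c3ccc(Cl)c(Cl)c3)c(SC(C)C)s2)c(C(=O)O)c1-c1cccc(F)c1`. Relative to compound 3 the change is 3-fluorophenyl in place of 3-methoxy-5-(trifluoromethyl)phenyl on an aromatic carbon. Every step measured so far in this assay alters the group at the same aromatic carbon, so all three bear on the question, but none of them places 3-fluorophenyl against 3-methoxy-5-(trifluoromethyl)phenyl directly. What the steps do show is that this position moves the number strongly, with only compound 3 reaching the lower range. Compound 4 is therefore expected to fall back toward the numbers of compounds 1 and 2, with a step of a 3.3-fold higher number from compound 3 to compound 4 (0.51 log units; beyond the scatter) as the estimated size. For compound 4 the expected value in this assay is 4500 nM, in the range 1500 nM to 14000 nM.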

Compound 4, half-maximal effective concentration: 900 nM
The estimate for compound 4 lay 5.0-fold (0.70 log units) above the measured number; measured number outside the range, below it.
By their numbers in this assay, from the lowest: compounds 4 and 3 (each within the scatter of the next); then compounds 2 and 1 (each within the scatter of the next).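

In this assay there is a 1.5-fold lower number from compound 3 to compound 4 (0.19 log units; within the scatter), so 3-fluorophenyl, with fewer heavy atoms and 0 hydrogen-bond acceptors against 1, is not separated from 3-methoxy-5-(trifluoromethyl)phenyl on this read-out, and compound 3 no longer stands alone in the lower range at this aromatic carbon. The same change set against the other two groups gives a 12-fold lower number from compound 2 to compound 4 (1.09 log units; beyond the scatter) and a 22-fold lower number from compound 1 to compound 4 (1.35 log units; beyond the scatter), which shows that among the compounds shown neither a methoxy nor a trifluoromethyl group on the phenyl ring is required to reach that range. Nothing at hand bears on why these groups separate as they do.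

Open, on these data alone, is whether an amine, a carboxylic acid or a longer chain carried on the phenyl ring at this aromatic carbon would stay with compounds 3 and 4 or fall back toward compounds 1 and 2. Also open, as far as these compounds go, is how an unsubstituted phenyl would compare with 3-fluorophenyl, and so whether the fluorine contributes at all.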